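A few compounds are considered here, and "the series" means these few. Any claim that something is new, unique, unknown or untested is made for them only; others in the source may bear on it.

Of the compounds shown here, three sharing one core have been measured in an assay on isolated protein with Bile acid receptor (Homo sapiens) as the target; on this read-out higher numbers stand for an effect only at larger amounts of compound and lower numbers for an effect already at smaller amounts. Compound 1 `COC(=O)/C=C/c1cccc(N(Cc2ccc(/C=C/c3scnc3C)cc2)C(=O)C(C)C)c1` gives 228 nM. Compound 2 `COC(=O)/C=C/c1cccc(N(Cc2ccc(-c3ccc(C)cc3)cc2)C(=O)C(C)C)c1` gives 118 nM. Compound 3 `COC(=O)/C=C/c1cccc(N(Cc2ccc(-c3cc(Cl)ccc3OC)cc2)C(=O)C(C)C)c1` gives 226 nM. The number for compound 3 is indistinguishable from that of compound 1, shown by a 1.0-fold lower number from compound 1 to compound 3 (0.00 log units; within the scatter), and it sits within the scatter of compound 2 as well, shown by a 1.9-fold higher number from compound 2 to compound 3 (0.28 log units; within the scatter). The remaining pair, a 1.9-fold lower number from compound 1 to compound 2 (0.29 log units; within the scatter), also stays within the scatter, so nothing separates the three.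

Compound 4 `COC(=O)/C=C/c1cccc(N(Cc2ccc(-c3cccc(OC)c3)cc2)C(=O)C(C)C)c1` differs from compound 3 only at one aromatic carbon: 3-methoxyphenyl in place of 5-chloro-2-methoxyphenyl on an aromatic carbon. Every step that bears on this change swaps one group at the same place for another, and each of them, whether the ethenyl-linked thiazole of compound 1, the 4-methylphenyl of compound 2 or the 5-chloro-2-methoxyphenyl of compound 3, produced no movement beyond the scatter. Among the compounds with values here, a 3-methoxyphenyl at this place therefore has no precedent in this set, but the three swaps that do exist suggest that the number is not sensitive to what sits there.

Compound 4 is thus expected to give about 170 nM, with a likely range from 70 nM to 420 nM. The estimated step from compound 3 is a 1.3-fold lower number from compound 3 to compound 4 (0.12 log units; within the scatter), expected to stay within the scatter.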

Compound 4, half-maximal effective concentration: 72 nM
Estimate against measurement, compound 4: 2.4-fold (0.37 log units) above; measured number inside the range.
By their numbers in this assay, from the lowest: compounds 4, 2, 3 and 1 (each within the scatter of the next, the first and the last beyond it).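

This place on the core is less indifferent than the first three compounds suggested, since in this assay two steps now clear the scatter: a 3.1-fold lower number from compound 3 to compound 4 (0.50 log units; beyond the scatter) and a 3.2-fold lower number from compound 1 to compound 4 (0.50 log units; beyond the scatter) both point to an effect at smaller amounts of compound with 3-methoxyphenyl. The third step, a 1.6-fold lower number from compound 2 to compound 4 (0.21 log units; within the scatter), stays within the scatter, so 3-methoxyphenyl and 4-methylphenyl cannot be told apart here, and the choice of aryl group matters only for some pairs. The swap from compound 3 also changes two things at once: the chlorine leaves and the methoxy group moves from the 2-position of the ring to the 3-position. The step belongs to the pair of changes and not to either one alone.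

The data shown give no reason for this step. Still open, on these data alone, is how a 2-methoxyphenyl, a 3-chlorophenyl or a plain phenyl would read at this place, which could separate the loss of the chlorine from the shift of the methoxy group, and whether a 3-aminophenyl would fit the same trend.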